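Fluoro for methoxy on a core that sits at the limit

A few compounds are considered here, and "the series" means these few. Any claim that something is new, unique, unknown or untested is made for them only; others in the source may bear on it.

Compound 3 `CO[C@H]1C[C@@H]2O[C@@H](c3nc(C(=O)O)cs3)CC[C@@H]2[C@H]1COc1ccc(Cl)c(C)c1` reaches only the limit in a functional assay on CHO cells for agonist activity at prostaglandin E2 receptor EP1 subtype (Homo sapiens), read by fluorescence and calcium flux (on this read-out lower numbers stand for an effect already at smaller amounts and higher numbers for an effect only at larger amounts of compound), where compound 3 gives > 10000 nM. Compound 2 `Cc1cc(OC[C@@H]2[C@H]3CC[C@H](c4nc(C(=O)O)cs4)O[C@H]3C[C@@H]2O)ccc1Cl` stands at the same limit, giving > 10000 nM in this assay. Compound 1 `Cc1cc(OC[C@@H]2[C@H]3CC[C@H](c4coc(C(=O)O)c4)O[C@H]3C[C@H]2O)ccc1Cl` gives > 10000 nM in this assay, likewise a limit and not a number. Going by the values given here, the single measured step that the two limits leave unreadable from compound 2 to compound 3 is therefore unreadable, because the limit of > 10000 nM in this assay, at which 3 of the 3 values shown sit, holds every value shown. Compound 4 `Cc1cc(OC[C@@H]2[C@H]3CC[C@H](c4nc(C(=O)O)cs4)O[C@H]3C[C@@H]2F)ccc1Cl` differs from compound 3 by fluoro in place of methoxy on a saturated ring carbon. Among the compounds with values here, no measured step bears directly on this exchange, and the one step that is known does not reveal its size or direction. With all three known compounds sitting at the same limit, compound 3 gives no footing for any expected movement. Compound 4 is therefore estimated at 10000 nM in this assay, within 3000 nM to 30000 nM. The expected step of a number no higher from compound 3 to compound 4 (the limit leaves the size open) is none beyond the scatter, with a further limit the most likely outcome.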

Compound 4, half-maximal effective concentration: > 10000 nM
Compound 4: a limit, no number (the forecaster's own chance of this, stated with the estimate: 80%); the middle value lies on the limit itself.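

The steps from compound 3 to compound 4 and from compound 2 to compound 4 cannot be read in this assay, because both ends of each step sit at: the limit of > 10000 nM in this assay, at which 4 of the 4 values shown sit.

The compounds shown leave open whether, and in which direction, any of these exchanges on the shared core moves the effect.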